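The compounds below may be only part of what the source reports. "The series", "measured", "known", "first", "only" and "open" are said of these compounds alone.

Compound 1 `O=C(OC1CCC(CN2CCN(c3cc(=O)c4cc(C(F)(F)F)cc([N+](=O)[O-])c4s3)CC2)CC1)C1CCCCC1` and compound 2 `O=C(OC1CCC(CN2CCN(c3cc(=O)c4cc(C(F)(F)F)cc([N+](=O)[O-])c4s3)CC2)CC1)c1ccco1` share one core and differ only in the group on a carbonyl carbon. In an ADME assay on cells (Hepatocyte, Homo sapiens) for metabolic stability (a higher number here means that the compound lasts longer, a lower number that the compound disappears faster), compound 1 gives 0.0967 h, and compound 2 gives 0.075 h. Among the measured compounds shown here, the step of a 1.3-fold lower number from compound 1 to compound 2 (0.11 log units; within the scatter) came with furan-2-yl in place of cyclohexyl on a carbonyl carbon, so the two numbers measured so far sit within the scatter of each other and compound 1 cannot be set apart from compound 2. Compound 3 `O=C(OC1CCC(CN2CCN(c3cc(=O)c4cc(C(F)(F)F)cc([N+](=O)[O-])c4s3)CC2)CC1)c1ccc(F)cc1` is not yet measured; it differs from compound 1 by 4-fluorophenyl in place of cyclohexyl on a carbonyl carbon. For the measured compounds named here, the only measured step that bears on this change is the one from compound 1 to compound 2, and it stayed within the scatter, so no shift beyond the scatter is expected in this assay here either. The step expected is a 1.1-fold lower number from compound 1 to compound 3 (0.03 log units; within the scatter). Compound 3 is thus estimated at 0.09 h, within a range from 0.04 h to 0.2 h.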

Compound 3, half-life: 0.0983 h
The estimate for compound 3 lay 1.1-fold (0.04 log units) below the measured number; measured number inside the range.
By their numbers in this assay, from the lowest: compounds 2, 1 and 3 (each within the scatter of the next).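

In this assay, 4-fluorophenyl in place of cyclohexyl gives a 1.0-fold higher number from compound 1 to compound 3 (0.01 log units; within the scatter) and 4-fluorophenyl in place of furan-2-yl gives a 1.3-fold higher number from compound 2 to compound 3 (0.12 log units; within the scatter) on the same carbonyl carbon. The earlier pair compared only cyclohexyl and furan-2-yl; this result adds a six-membered aromatic ring carrying fluorine, and all three compounds still sit within the scatter of one another. No evidence at hand gives a reason for this closeness.
From the compounds shown here alone, it remains open whether a different kind of group on this carbonyl carbon, such as an amine or a carboxylic acid, would move the number beyond the scatter. Going by these compounds, it also remains open whether a change elsewhere in the shared core would do so, as all three compounds carry that core unchanged.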